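Chloro-Methylphenyl in Place of Trifluoromethylphenyl on the Triazole

This account rests on a few compounds, and the source may have more. Where it says the series, first, only, none or still open, it means among the compounds named here.

Among the compounds with values here, in a functional assay on HCT-116 cells (Homo sapiens) for antiproliferative activity, read by MTT assay, with a stated time of 48 h (a lower number here means a stronger inhibitor, a higher number a weaker inhibitor), compound 3 `N#CC1=C(N)Oc2c(N)cc3nc4ccccc4nc3c2C12C(=O)N(Cc1cnnn1-c1cccc(C(F)(F)F)c1)c1ccccc12` gives 18900 nM, the only outright number among the three measured compounds. Compound 1 `Cc1ccc(Cl)cc1-n1nncc1CN1C(=O)C2(C(C#N)=C(N)Oc3c2c2nc4ccccc4nc2c2ccccc32)c2ccccc21` gives only the limit > 50000 nM in this assay. Compound 2 `N#CC1=C(N)Oc2c(c3nc4ccccc4nc3c3ccccc23)C12C(=O)N(Cc1cnnn1-c1ccc(Cl)c(Cl)c1)c1ccccc12` likewise gives only the limit > 50000 nM. Within the data shown here, the single measured step, a step that the two limits leave unreadable from compound 1 to compound 2, cannot be sized because both of its values sit at the limit of > 50000 nM in this assay, at which 2 of the 3 values shown sit. Compound 4 `Cc1ccc(-n2nncc2CN2C(=O)C3(C(C#N)=C(N)Oc4c(N)cc5nc6ccccc6nc5c43)c3ccccc32)cc1Cl` differs from compound 3 by 3-chloro-4-methylphenyl in place of 3-(trifluoromethyl)phenyl on an aromatic nitrogen. Among the measured compounds shown here, no measured step shows what such an aryl exchange does on the core of compound 3, and the two limits give no size for any aryl exchange at all. Compound 4 is therefore expected to stay close to compound 3, with an estimated step of a 1.3-fold higher number from compound 3 to compound 4 (0.12 log units; within the scatter) not beyond the scatter. The estimate for compound 4 is 25000 nM, between 9000 nM and 60000 nM.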

Compound 4, half-maximal inhibitory concentration: > 50000 nM
Compound 4 gave a limit, no number; the forecaster's own chance of this, stated with the estimate: 35%; middle value at least 2.0-fold (0.30 log units) away from the limit.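

In this assay, the aryl group on this aromatic nitrogen proves to matter on the core of compound 3, with an at least 2.6-fold higher number from compound 3 to compound 4 (0.42 log units; beyond the scatter) for 3-chloro-4-methylphenyl in place of 3-(trifluoromethyl)phenyl. The earlier pair of limits gave no such reading, and this step has a lower bound only. Compound 3 alone stands clear of the limit: the limit of > 50000 nM in this assay, at which 3 of the 4 values shown sit.

Still open, as far as these compounds go, is how far the number rises past that limit for compound 4. Also open, from the compounds shown here alone, is whether a methoxy group or a carboxylic acid on this aryl ring would keep a measurable number.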